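This account rests on a few compounds, and the source may have more. Where it says the series, first, only, none or still open, it means among the compounds named here.

Of the compounds shown here, three have been measured in a functional assay on A-431 cells (Homo sapiens) for antiproliferative activity, read by MTT assay, with a stated time of 72 h; a higher number here means a weaker inhibitor, a lower number a stronger inhibitor. Compound 1 `COc1cc2ncnc(Nc3ccc(Br)cc3)c2cc1OCCCCC(=O)Nc1ccc(S(N)(=O)=O)cc1` gives 6570 nM. Compound 2 `COc1ccc(Nc2ncnc3cc(OC)c(OCCCCC(=O)Nc4ccc(S(N)(=O)=O)cc4)cc23)cc1OC` gives 35400 nM, and compound 3 `NS(=O)(=O)c1ccc(NC(=S)Nc2ccc3ncnc(Nc4cccc(C(F)(F)F)c4)c3c2)cc1` gives 21700 nM. Of the three numbers, compound 3 has the second highest; its value and that of compound 2 lie within the scatter of each other, while compound 1 has a clearly lower number than compound 3.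

Compound 4 `NS(=O)(=O)c1ccc(NC(=S)Nc2ccc3ncnc(Nc4ccc(C(F)(F)F)cc4)c3c2)cc1` has the same atoms as compound 3 joined differently: 4-(trifluoromethyl)phenyl in place of 3-(trifluoromethyl)phenyl on a nitrogen on an aromatic ring. Among the measured compounds shown here, the only measured step that touches the same part of the molecule is a 5.4-fold higher number from compound 1 to compound 2 (0.73 log units; beyond the scatter), which swapped one substituted phenyl for another on that nitrogen and gave a modest change. Nothing measured here moves a trifluoromethyl group from one position of the phenyl ring to another, so that step offers only a loose guide. A change near the scatter, possibly toward a higher number, is expected; the estimated step is a 1.4-fold higher number from compound 3 to compound 4 (0.14 log units; within the scatter). Compound 4 is therefore expected to give 30000 nM, within a range from 10000 nM to 90000 nM.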

Compound 4, half-maximal inhibitory concentration: 18000 nM
Beside the measured number, compound 4's estimate is 1.7-fold (0.22 log units) above it; the range from low to high includes it.
By their numbers in this assay, from the lowest: compound 1; then compounds 4, 3 and 2 (each within the scatter of the next).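

Moving the trifluoromethyl group, with 4-(trifluoromethyl)phenyl in place of 3-(trifluoromethyl)phenyl on the nitrogen, gives a 1.2-fold lower number from compound 3 to compound 4 (0.08 log units; within the scatter) in this assay, so the two compounds cannot be told apart. The earlier step, a 5.4-fold higher number from compound 1 to compound 2 (0.73 log units; beyond the scatter), exchanged one set of phenyl substituents for another, whereas this pair keeps the same atoms and only joins them differently, and that rearrangement leaves no readable mark on the result. Nothing available here explains this outcome.

On these data alone, whether a nitrile or a carboxylic acid in place of the trifluoromethyl group on this phenyl ring would separate itself from compound 3 and compound 4 remains open. Compound 1 differs from both in more than one place, so what sets its number apart also remains unsettled.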